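Chain extension on the shared core: compound 2 to compound 3

This account rests on a few compounds, and the source may have more. Where it says the series, first, only, none or still open, it means among the compounds named here.

Going by the values given here, compound 2 `CCCCCCc1nc(O)cc(O)n1` stands highest of the two numbers measured so far in a functional assay on HEK293 cells for agonist activity at G-protein coupled receptor 84 (Homo sapiens), read by calcium flux (on this read-out higher numbers stand for larger maximal responses and lower numbers for smaller maximal responses), giving 99.7%; the nearest is compound 1 `N#CCCCCc1nc(O)cc(O)n1`, which in this assay gives 55.2%. Among the compounds with values here, the one measured step, a number 44.5 percentage points higher from compound 1 to compound 2 (beyond the scatter), also concerns the saturated chain. Compound 3 `CCCCCCCCCc1nc(O)cc(O)n1` differs from compound 2 by propyl in place of hydrogen on a saturated chain carbon, six bonds along the chain from an aromatic carbon. Within the data shown here, no measured pair shows this exact change; the step from compound 1 to compound 2 is the only one bearing on the chain, and it was large and upward. Compound 2 is already close to the reference maximum, so little room remains above it. Compound 3 is therefore expected to change little, a number 4.7 percentage points lower from compound 2 to compound 3 (within the scatter), with the main uncertainty on the downside. The estimate for compound 3 in this assay is 95%, between 65% and 115%.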

Compound 3, largest response reached (reported as percent of maximum), in percent of the reference or control that the assay uses: 84.1%
Compound 3: the middle estimate sits 10.9 percentage points above what was measured; low and high end bracket the measured number.
By their numbers in this assay, from the lowest: compound 1; then compound 3; then compound 2.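

In this assay, extending the saturated chain does not hold the response at the level of compound 2: propyl in place of hydrogen, six bonds along the chain from an aromatic carbon, gives a number 15.6 percentage points lower from compound 2 to compound 3 (beyond the scatter). The longer chain still retains more response than the cyano-ended chain, with pentyl in place of cyano giving a number 28.9 percentage points higher from compound 1 to compound 3 (beyond the scatter), so this position tolerates the added carbons only at some cost in maximal response. Nothing measured here accounts for the decline.

Open, going by these compounds, is whether a longer chain still would lower the response further, and whether the fall from compound 2 to compound 3 is gradual or abrupt. A chain ending in a carboxylic acid or an amine would show whether the end of the chain accepts anything other than plain alkyl.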